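A Fluorinated Chain on a Core That Barely Inhibits

A few compounds are considered here, and "the series" means these few. Any claim that something is new, unique, unknown or untested is made for them only; others in the source may bear on it.

Compound 1 `CCSCCC12CCC(c3nnc(-c4ccccc4C(F)(F)F)n3C)(CC1)CC2` gives > 4000 nM in an assay on CHO-K1 cells for inhibition of 11-beta-hydroxysteroid dehydrogenase type 2 (Mus musculus), read by scintillation proximity assay (on this read-out higher numbers stand for weaker inhibition and lower numbers for stronger inhibition), which is a limit of the assay and not a number.
Compound 2 `Cn1c(-c2ccccc2C(F)(F)F)nnc1C12CCC(CCS(C)(=O)=O)(CC1)CC2` gives > 4000 nM in this assay, again only a limit.
Compound 3 `CCCCCC12CCC(c3nnc(-c4ccccc4C(F)(F)F)n3C)(CC1)CC2` gives > 4000 nM in this assay, again only a limit.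

Every measured value sits at the limit of > 4000 nM in this assay, at which 3 of the 3 values shown sit, so compound 1 stands nowhere definite on the numbers shown; it is known only to be a weak inhibitor. The steps a step that the two limits leave unreadable from compound 1 to compound 2, a step that the two limits leave unreadable from compound 1 to compound 3 and a step that the two limits leave unreadable from compound 2 to compound 3 cannot be read in size or direction. Compound 4 `CC(F)CCCC12CCC(c3nnc(-c4ccccc4C(F)(F)F)n3C)(CC1)CC2` differs from compound 1 by 2-fluoropropyl in place of ethylsulfanyl on a saturated chain carbon, two bonds along the chain from a saturated ring carbon. With no readable step among the measured compounds, no particular size or direction is expected; the likeliest outcome is another limit. Compound 4 is therefore estimated at 8000 nM, with a range from 2500 nM to 30000 nM. This estimate means a step that the limit leaves unreadable from compound 1 to compound 4.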

Compound 4, half-maximal inhibitory concentration: > 4000 nM
Compound 4 gave a limit, no number; the forecaster's own chance of this, stated with the estimate: 80%; the middle value lies beyond the limit too.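

Compound 4 gives only a limit, and no step from compound 1, compound 2 or compound 3 to compound 4 can be read in this assay: the limit of > 4000 nM in this assay, at which 4 of the 4 values shown sit.
The compounds shown leave open how strongly each one actually inhibits, and whether changing the chain on the shared core alters that.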